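A few compounds are considered here, and "the series" means these few. Any claim that something is new, unique, unknown or untested is made for them only; others in the source may bear on it.

Values measured in a functional assay on NCI-H1581 cells (Homo sapiens) for antiproliferative activity, read by CCK-8 assay, with a stated time of 72 h (on this read-out higher numbers stand for weaker inhibition and lower numbers for stronger inhibition), for the three compounds:
compound 1 `COc1cc(OC)c(Cl)c(-c2ccc3c(NC(=O)c4ccc(N5CCN(C(C)C)CC5)cc4)n[nH]c3n2)c1Cl` gives 1.4 nM
compound 2 `COc1cc(OC)c(Cl)c(-c2ccc3c(NC(=O)c4ccc(N5CCN(C)CC5)cc4Cl)n[nH]c3n2)c1Cl` gives 27.6 nM
compound 3 `COc1cc(OC)c(Cl)c(-c2ccc3c(NC(=O)c4ccc(N5CCN(C)CC5)c(Cl)c4)n[nH]c3n2)c1Cl` gives 191 nM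

Among these three numbers, compound 2 (27.6 nM) stands second highest, and it lies beyond the scatter from both neighbours: compound 3 has the higher number and compound 1 the lower. Compound 4 `COc1cc(N2CCN(C)CC2)ccc1C(=O)Nc1n[nH]c2nc(-c3c(Cl)c(OC)cc(OC)c3Cl)ccc12` has yet to be measured in this assay and departs from compound 2 by a single change, methoxy in place of chloro on an aromatic carbon. This carbon is ortho to a large group and meta to a 4-methylpiperazin-1-yl group. Going by the values given here, no measured pair isolates this exchange, so the expectation is only loosely founded. It rests on compound 1 (1.4 nM), which carries no chloro on that ring, although it also differs at the piperazine. A moderate move toward stronger inhibition is therefore expected, and the estimated change is a 2.8-fold lower number from compound 2 to compound 4 (0.44 log units; beyond the scatter) in this reading. For compound 4 the estimated value is 10 nM (expected range 2 nM to 50 nM).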

Compound 4, half-maximal inhibitory concentration: 525 nM
Estimate against measurement, compound 4: 53-fold (1.72 log units) below; measured number above the stated range.
By their numbers in this assay, from the lowest: compound 1; then compound 2; then compound 3; then compound 4.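

In this assay, putting methoxy in place of chloro on this aromatic carbon, ortho to a large group and meta to a 4-methylpiperazin-1-yl group, gives a 19-fold higher number from compound 2 to compound 4 (1.28 log units; beyond the scatter) and so costs much inhibition. The result shows that, with the rest of compound 2 kept unchanged, this carbon is sensitive to the exchange of one small group for another, and that methoxy is strongly disfavoured here relative to chloro. Nothing measured on these compounds accounts for the size of this step.

It remains open whether the loss belongs to methoxy itself or to the departure of chloro: no compound shown carries a plain hydrogen at this carbon together with the 4-methylpiperazin-1-yl group. Going by these compounds, how fluoro, an amine or a hydroxyl group at this carbon would read in this assay also remains unknown.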